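The compounds below may be only part of what the source reports. "The series", "measured", "known", "first", "only" and "open" are said of these compounds alone.

In a physicochemical assay for lipophilicity (a lower number here means a more polar compound, a higher number a more lipophilic compound), compound 1 (`CC(/C=C/CC(C)CCCC(C)C)=C\C(=O)OC(C)C`) reads 7.15 and stands second highest of three numbers, under compound 3 (`CC(/C=C/CC(C)CCCC(C)C)=C\C(=O)OCc1ccccc1`) at 7.87, with compound 2 (`CC#CCOC(=O)/C=C(C)/C=C/CC(C)CCCC(C)C`) at 6.4 the lowest on the same scale. Compound 4 (`CC(=O)OC(C)(C)CCCC(C)C/C=C/C(C)=C/C(=O)OC(C)C`) is compound 1 with one change: acetoxy in place of hydrogen on a saturated chain carbon bound to three saturated chain carbons. For the measured compounds named here, no measured step makes this change. Changing the group on an oxygen next to a carbonyl group gave a number 0.75 log units lower from compound 1 to compound 2 (beyond the scatter) and a number 0.72 log units higher from compound 1 to compound 3 (beyond the scatter) as modest steps, and a number 1.47 log units higher from compound 2 to compound 3 (beyond the scatter) as a large one, so they show only how far numbers in this small set have moved. Acetoxy brings hydrogen-bond acceptors where compound 1, at 7.15 here, has a hydrogen, and a modest step to a lower number, similar in size to a number 0.75 log units lower from compound 1 to compound 2 (beyond the scatter) and in the same direction, is expected. The estimated step is a number 0.85 log units lower from compound 1 to compound 4 (beyond the scatter) on this scale. For compound 4 the estimated value is 6.3 within an expected range from 5.7 to 6.9 for now.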

Compound 4, partition coefficient: 5.98
Compound 4: the middle estimate sits 0.32 log units above what was measured; the measured number falls inside the stated range.
By their numbers in this assay, from the lowest: compound 4; then compound 2; then compound 1; then compound 3.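

In this assay, for the compounds shown here, acetoxy on a saturated chain carbon bound to three saturated chain carbons gives a number 1.17 log units lower from compound 1 to compound 4 (beyond the scatter) on the scale, so this place on the chain, untouched by the earlier steps, can also shift the number. This single change counts as a large step, whereas the two changes to the ester group starting from compound 1 counted as modest (a number 0.75 log units lower from compound 1 to compound 2 (beyond the scatter); a number 0.72 log units higher from compound 1 to compound 3 (beyond the scatter)). Nothing available here explains the size of this step.

The compounds shown leave open whether a hydroxyl or an amine on this same carbon would move the number as far. They also leave open whether acetoxy would give a step of similar size with benzyl or but-2-yn-1-yl in place of isopropyl on the ester.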